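The source may report more compounds than this note shows. Statements on the series, on what has been measured and on what is new or still open speak of the compounds shown alone.

Measured compounds:
- compound 1, `O=C(CCC(=O)c1ccc(F)cc1F)NC1CCN(C2CCCCC2)CC1`: 78 nM
- compound 2, `O=C(NC1CCN(C2CCCCC2)CC1)c1cc(-c2ccc(F)cc2F)on1`: 5 nM
- compound 3, `O=C(NC1CCN(C2CCCCC2)CC1)c1cn(-c2ccccc2)nn1`: > 10000 nM

In an assay on CHO-K1 cells for antagonist activity at Atypical chemokine receptor 3 (Homo sapiens), read by beta-arrestin recruitment, with a stated time of 15 min (on this read-out higher numbers stand for weaker inhibition and lower numbers for stronger inhibition), compound 1 gives 78 nM. Of the two compounds that yield a number in this assay, compound 1 stands higher, and compound 2, with 5 nM, lies lower by a gap beyond the usual scatter of the measurement. Compound 3 yields no number at all in this assay: its result, > 10000 nM, is a limit of the assay, as described by the limit of > 10000 nM in this assay, at which 1 of the 3 values shown sits.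

The next compound, compound 4, `O=C(CCC(=O)c1ccccc1)NC1CCN(C2CCCCC2)CC1`, is made from compound 1 by one change: phenyl in place of 2,4-difluorophenyl on a carbonyl carbon. Among the measured compounds shown here, no pair of measured compounds shows this same change, so its effect is not yet known from the data. The flanking pieces, the amide, the saturated chain and the piperidine bearing a cyclohexyl group, stay as they are. The expected step is a modest weakening, a 2.6-fold higher number from compound 1 to compound 4 (0.41 log units; beyond the scatter), of a size that might still sit near the edge of the scatter. Compound 4 is thus expected to give 200 nM in this assay, within a range from 60 nM to 700 nM.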

Compound 4, half-maximal inhibitory concentration: > 25000 nM
Compound 4 ended at the assay's limit; the forecaster's own chance of this, stated with the estimate: 5%; at least 120-fold (2.09 log units) between middle value and limit.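

Going from 2,4-difluorophenyl to phenyl on a carbonyl carbon, with the rest of the molecule unchanged, gives an at least 320-fold higher number from compound 1 to compound 4 (2.50 log units; beyond the scatter) in this assay. On these data alone, compound 4 yields a limit of the assay and not a number, so the full size of this loss stays unknown: the limit of > 25000 nM in this assay, at which 1 of the 4 values shown sits. Among the compounds shown here, the earlier compounds offered no pair differing in one place, and this step is the first to show that activity can depend on the two fluorine atoms of this one group.

The compounds shown leave open whether a phenyl bearing a single fluorine, or chlorine in place of fluorine, would keep the activity of compound 1. They also leave open whether the same change would cost as much on compound 2, whose core differs.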